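The source may hold more compounds than are shown below. What is called first, only, known or untested is meant among the compounds shown, and "the series" means these compounds.

Compound 1 `O=C1CSC(c2ccc(O)cc2)N1CCN1CCCCC1` gives 76% in an ADME assay on Vero cells (Chlorocebus sabaeus) for cytotoxicity, read by neutral red uptake, tested at 394 ug/mL; a higher number here means a weaker effect of the compound at the concentration tested, a lower number a stronger effect. Compound 2 `O=C1CSC(c2ccc(F)cc2)N1CCN1CCCCC1` gives 52% in this assay.

Among the compounds with values here, compound 2 thus stands lowest of the two numbers, with compound 1 the only neighbour, and the gap is beyond the scatter. Within the data shown here, the single measured step, a number 24 percentage points lower from compound 1 to compound 2 (beyond the scatter), is the only guide; it swaps one small aromatic substituent for another and so bears only loosely on the next change. Compound 3 `O=C1CSC(c2ccc(Cl)cc2)N1CCN1CCCCC1` differs from compound 2 by chloro in place of fluoro on an aromatic carbon. Among the measured compounds shown here, with no closer precedent, a small step at most is expected for compound 3, a number 7 percentage points lower from compound 2 to compound 3 (within the scatter), giving an estimated 45% in this assay, most likely between 25% and 70%.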

Compound 3, a percentage reported as activity, at one concentration (the size of the read-out at that concentration, not a potency): 28%
Beside the measured number, compound 3's estimate is 17 percentage points above it; low and high end bracket the measured number.
By their numbers in this assay, from the lowest: compound 3; then compound 2; then compound 1.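

Chloro in place of fluoro gives a number 24 percentage points lower from compound 2 to compound 3 (beyond the scatter) in this assay, so exchanging one halogen for another at this position moves the number, and the earlier change from hydroxy to fluoro was not the only one that does. Chloro in place of hydroxy gives a number 48 percentage points lower from compound 1 to compound 3 (beyond the scatter), the largest step among these compounds. Nothing measured here explains either step. Going by these compounds, whether the number keeps falling with bromo remains open, as does where a methoxy group or an amine at this position would fall.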